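Indole-to-cyanobenzyl swap on the piperidine-linked oxazolidinone

The source may hold more compounds than are shown below. What is called first, only, known or untested is meant among the compounds shown, and "the series" means these compounds.

Compound 1 `COc1ccc2nccc(C3CN(C4CCN(Cc5cc6ccccc6[nH]5)CC4)C(=O)O3)c2c1` is the anchor of this pair. For the measured compounds named here, in an in vitro functional assay on RBL cells for antagonist activity at C-C chemokine receptor type 8 (Homo sapiens), read by FLIPR and calcium flux (a higher number here means a weaker inhibitor, a lower number a stronger inhibitor), compound 1 gives 25.1 nM, and this is the only plain number in the set. The other value recorded is the limit of < 50200 nM in this assay, at which 1 of the 2 values shown sits. Compound 2 `O=C1OC(c2cnc3ccccc3c2)CN1C1CCN(Cc2cc3ccccc3[nH]2)CC1` gives in this assay < 50200 nM, a limit of the assay and not a number. Going by the values given here, no step between measured compounds can be drawn, so nothing measured speaks to the size of the change ahead.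

Compound 3 `COc1ccc2nccc(C3CN(C4CCN(Cc5ccc(C#N)cc5)CC4)C(=O)O3)c2c1` is the compound to be measured. It differs from compound 1 in one place: 4-cyanophenyl in place of 1H-indol-2-yl on a saturated chain carbon bound to an amine nitrogen in a ring. Among the compounds with values here, with no measured step to lean on, the expectation is a modest loss in this assay, a step beyond the usual scatter but not a large one, so that a 3.2-fold higher number from compound 1 to compound 3 (0.50 log units; beyond the scatter) is what is expected. Compound 3 is therefore estimated at 80 nM in this assay, with a plausible range from 15 nM to 400 nM, and a small chance that only a limit is reported.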

Compound 3, half-maximal inhibitory concentration: 12600 nM
Estimate against measurement, compound 3: 160-fold (2.20 log units) below; the measured number lies above the stated range.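

The place on a saturated chain carbon bound to an amine nitrogen in a ring is far from indifferent to the group it carries: in this assay, 4-cyanophenyl in place of 1H-indol-2-yl gives a 500-fold higher number from compound 1 to compound 3 (2.70 log units; beyond the scatter). With the core of compound 1 left unchanged, this single exchange is enough to take a strong inhibitor to a weak one, so much of the activity of compound 1 depends on the (1H-indol-2-yl)methyl end of the molecule. No measurement shown gives a cause for this loss.

The exchange removes a five-membered aromatic ring and a hydrogen-bond donor and adds a nitrile in the same step, so the compounds shown do not tell which of these changes carries the loss. A plain benzyl, a 4-methoxybenzyl or a (1H-benzimidazol-2-yl)methyl at this place would begin to separate these contributions, and would show whether any group other than (1H-indol-2-yl)methyl keeps the activity of compound 1.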